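Iodo in place of amino on two inactive compounds

This account rests on a few compounds, and the source may have more. Where it says the series, first, only, none or still open, it means among the compounds named here.

Compound 1 `CC(=O)OC(C)n1cnc2c(Cl)nc(N)nc21` was tested in a functional assay on HT-29 cells (Homo sapiens) for inhibition; on this read-out lower numbers stand for stronger inhibition and higher numbers for weaker inhibition. There compound 1 gives only a limit of the assay, > 500000 nM, and no number. Compound 2 `CC(=O)OCCOn1cnc2c(Cl)nc(N)nc21` likewise reaches only a limit, giving > 500000 nM in this assay. Both values sit at the limit of > 500000 nM in this assay, at which 2 of the 2 values shown sit, so compound 1 cannot be set apart from compound 2 on these numbers. Compound 3 `CC(=O)OC(C)n1cnc2c(Cl)nc(I)nc21` differs from compound 1 by iodo in place of amino on an aromatic carbon. Within the data shown here, no measured pair changes that group, so the step is unknown; compound 3 is expected to stay near the limit, an expected step of a number no higher from compound 1 to compound 3 (the limit leaves the size open). The estimate for compound 3 is 500000 nM, from 100000 nM to 2000000 nM.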

Compound 3, half-maximal inhibitory concentration: 6420 nM
Compound 3: middle estimate off by 78-fold (1.89 log units), on the high side; the measured number lies below the stated range.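

Among these compounds, exchanging amino for iodo on the aromatic carbon between two ring nitrogen atoms is the first change here that registers in this assay, with a large drop in the read-out (an at least 77-fold lower number from compound 1 to compound 3 (1.89 log units; beyond the scatter)). This position therefore matters for the read-out on the core of compound 1, and compound 3 gives a measured number rather than a limit. The earlier compounds shown here showed only a limit: the limit of > 500000 nM in this assay, at which 2 of the 3 values shown sit.

Whether iodo itself is needed, or only the loss of amino, stays open, since bromo or a plain hydrogen at this position does not appear among these compounds. Going by these compounds, whether iodo acts likewise on the core of compound 2 also stays open.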